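The source may hold more compounds than are shown below. What is called first, only, known or untested is meant among the compounds shown, and "the series" means these compounds.

Working notes on a small set of purine-type alkylating compounds tested in a functional assay on NCI-H522 cells (Homo sapiens) for cytotoxicity, read by sulforhodamine B assay, with a stated time of 48 h; on this read-out lower numbers stand for stronger inhibition of growth and higher numbers for weaker inhibition of growth.

Compound 1 `ClCc1ccc(Cn2cnc3c(Cl)ncnc32)cc1` carries a single chloro group on the six-membered aromatic ring of the core. In this assay compound 1 returns only a limit, > 100000 nM, and no number. Compound 3 `ClCc1ccc(Cn2cnc3c(Cl)nc(Cl)nc32)cc1` differs from compound 1 by chloro in place of hydrogen on an aromatic carbon. In this assay compound 3 gives 46800 nM. The step recorded is an at least 2.1-fold lower number from compound 1 to compound 3 (0.32 log units; beyond the scatter); its size can only be given as a lower bound, since it rests on (the limit of > 100000 nM in this assay, at which 1 of the 3 values shown sits).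

Compound 2 `ClCc1cccc(Cn2cnc3ncnc(Cl)c32)c1` has the same atoms as compound 1 joined differently; the difference between the two cores is not broken down here. In this assay compound 2 gives 24000 nM. The values of compound 2 and compound 3 lie within the usual scatter of each other, so nothing is said about their order.

Compound 4 `ClCc1cccc(Cn2cnc3nc(Cl)nc(Cl)c32)c1` is not yet measured. It differs from compound 2 by chloro in place of hydrogen on an aromatic carbon, which is the same change as that from compound 1 to compound 3, made on the same kind of place.

Going by the values given here, for compound 4 a step of about a 2.0-fold lower number from compound 2 to compound 4 (0.30 log units; within the scatter) is expected, on the single precedent of an at least 2.1-fold lower number from compound 1 to compound 3 (0.32 log units; beyond the scatter), with the caution that the earlier step is only a lower bound and that compound 2 already sits below the limit where compound 1 stood. The estimate for compound 4 in this assay is 12000 nM, expected to fall between 4000 nM and 40000 nM.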

Compound 4, concentration for total growth inhibition: 3540 nM
For compound 4 the middle estimate is 3.4-fold (0.53 log units) above the measured one; measured number outside the range, below it.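

In this assay, chloro in place of hydrogen on the aromatic carbon between two ring nitrogen atoms gives a 6.8-fold lower number from compound 2 to compound 4 (0.83 log units; beyond the scatter), so on both pairs shown the change goes the same way and lies beyond the scatter. This supports carrying the direction of the change from one core to the other, within these two pairs only, but the two steps cannot be compared in size: the same change on two cores in this assay, an at least 2.1-fold lower number (0.32 log units; beyond the scatter) from compound 1 to compound 3 and a 6.8-fold lower number (0.83 log units; beyond the scatter) from compound 2 to compound 4; the limit leaves it open whether they differ It remains unshown whether the core of compound 2 responds more strongly to the change than the core of compound 1, or whether a single size of step would serve for estimates on a further core, since the earlier step has only a lower bound, with compound 1 recorded as a limit and not a number: the limit of > 100000 nM in this assay, at which 1 of the 4 values shown sits.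

The compounds shown leave open whether an amine or a methoxy group in that same place between two ring nitrogen atoms would move the number as chloro does. They also leave open whether the step survives when the chloromethyl group gives way to a hydroxymethyl group, and whether a third core would follow the same direction.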